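Removing a Chlorine From Two Related Cores

This account rests on a few compounds, and the source may have more. Where it says the series, first, only, none or still open, it means among the compounds named here.

Compound 1 `O=C1C2=C(C(=O)c3ncccc31)C1(CS2)NC(=O)N(c2ccc(Cl)cc2)C1=O` and compound 2 `O=C1C2=C(C(=O)c3ncccc31)C1(CS2)NC(=O)N(c2ccccc2)C1=O` are built on one shared core and differ in a single place: hydrogen in place of chloro on an aromatic carbon. In a functional assay on MT4 cells (Homo sapiens) for antiproliferative activity, read by MTT assay, with a stated time of 96 h (a higher number here means a weaker inhibitor, a lower number a stronger inhibitor), compound 1 gives 10 nM, while compound 2 gives 25 nM. That amounts to a 2.5-fold higher number from compound 1 to compound 2 (0.40 log units; beyond the scatter), so on this core taking the chloro away makes the compound a somewhat weaker inhibitor.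

Compound 3 `O=C1NN(c2ccc(Cl)cc2)C(=O)C2(CSC3=C2C(=O)c2ncccc2C3=O)N1` carries the same 4-chlorophenyl group but sits on a different core; how the two cores differ is not broken down here. In this assay compound 3 gives 150 nM, the highest of the three numbers, and its steps to compound 2 and to compound 1 are both beyond the usual scatter.

Compound 4 `O=C1NN(c2ccccc2)C(=O)C2(CSC3=C2C(=O)c2ncccc2C3=O)N1` has not yet been measured. It differs from compound 3 by hydrogen in place of chloro on an aromatic carbon, and the place of the change is described in the same words as for the pair of compound 1 and compound 2, so it is the same change made on the other core. Within the data shown here, the one earlier example, a 2.5-fold higher number from compound 1 to compound 2 (0.40 log units; beyond the scatter), is the only guide, and it comes from a different core, so the expectation is uncertain. The step is expected to be a 2.5-fold higher number from compound 3 to compound 4 (0.40 log units; beyond the scatter) in this assay, of about the size seen before. On that basis compound 4 is estimated at 375 nM, most likely falling between 170 nM and 850 nM.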

Compound 4, half-maximal inhibitory concentration: 150 nM
Compound 4: middle estimate off by 2.5-fold (0.40 log units), on the high side; the measured number lies below the stated range.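

In this assay, putting hydrogen in place of chloro on the core of compound 3 gives no change at the digits printed from compound 3 to compound 4 (within the scatter), so this pair shows no measurable effect of the swap, whereas the pair on the other core showed a step beyond the scatter. Set side by side, however, the two steps cannot be told apart, since each carries its own measurement scatter and the gap between them has to be judged against both: the same change on two cores in this assay, a 2.5-fold higher number (0.40 log units; beyond the scatter) from compound 1 to compound 2 and no change at the digits printed (within the scatter) from compound 3 to compound 4, 2.5-fold (0.40 log units) apart, within the scatter of two such steps

This means the data do not show that the core alters what the change does, and they do not prove that the change carries over unaltered either, as a single pair on each core is too little to settle the question either way.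

The compounds shown carry only chloro or hydrogen on the phenyl ring, so it remains open whether a fluoro, a methoxy or an amine at the same place would follow one core, both or neither. On these data alone, it is also open how either core would respond if the phenyl ring gave way to a longer chain or to a group bearing a carboxylic acid.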